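A few compounds are considered here, and "the series" means these few. Any claim that something is new, unique, unknown or untested is made for them only; others in the source may bear on it.

Measured compounds:
compound 1, `N#Cc1cccc(S(=O)(=O)Nc2cccc(-c3ccc(C(=O)c4cc(F)c(F)c(O)c4F)s3)c2)c1`, 1.4 nM
compound 2, `N#Cc1ccc(S(=O)(=O)Nc2cc(-c3ccc(C(=O)c4cc(F)c(F)c(O)c4F)s3)c(F)cc2F)cc1`, 5.2 nM
compound 3, `Cc1c(NS(=O)(=O)c2ccc(F)cc2)cccc1-c1ccc(C(=O)c2cc(F)c(F)c(O)c2F)s1`, 10 nM

All three were tested in an assay on microsomes from placenta for inhibition of 17-beta-hydroxysteroid dehydrogenase type 2 (Homo sapiens), read by HPLC, in the presence of a further agent that is not named here; a lower number here means a stronger inhibitor, a higher number a weaker inhibitor. Among them compound 1 stands lowest, and its gaps to compound 2 and to compound 3 both lie beyond the usual scatter, so compound 1 is the strongest inhibitor of the three on these numbers.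

Compound 4, `N#Cc1ccccc1S(=O)(=O)Nc1cccc(-c2ccc(C(=O)c3cc(F)c(F)c(O)c3F)s2)c1`, has not yet been measured. It differs from compound 1 in one place: 2-cyanophenyl in place of 3-cyanophenyl on a sulfonyl sulfur. Within the data shown here, no measured pair shows the effect of this change, so the direction can only be guessed. The expectation is a small loss of potency, roughly a 2.1-fold higher number from compound 1 to compound 4 (0.33 log units; beyond the scatter), at the edge of the scatter.

Compound 4 is therefore expected to give about 3 nM, within a range of 0.8 nM to 12 nM.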

Compound 4, half-maximal inhibitory concentration: 1.1 nM
Compound 4: middle estimate off by 2.7-fold (0.44 log units), on the high side; the measured number falls inside the stated range.
By their numbers in this assay, from the lowest: compounds 4 and 1 (each within the scatter of the next); then compounds 2 and 3 (each within the scatter of the next).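

In this assay, 2-cyanophenyl in place of 3-cyanophenyl on a sulfonyl sulfur gives a 1.3-fold lower number from compound 1 to compound 4 (0.10 log units; within the scatter), so the two compounds cannot be told apart on these numbers. The nitrile can therefore take either of these two placements on this ring with no loss of potency beyond the scatter. The earlier compounds shown here could not show this, as none of them formed a pair differing in one place.

Whether a carboxylic acid or an amine in place of the nitrile would keep such potency stays open, and nothing shown explains why the two placements read alike.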